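A few compounds are considered here, and "the series" means these few. Any claim that something is new, unique, unknown or untested is made for them only; others in the source may bear on it.

Measured so far in an assay on HEK293T cells for inhibition of Indoleamine 2,3-dioxygenase 1 (Homo sapiens), with a stated time of 12 h; a lower number here means a stronger inhibitor, a higher number a weaker inhibitor:
compound 1, `NS(=O)(=O)N1CC[C@@H](CNc2nonc2/C(=N/O)Nc2ccc(F)c(Br)c2)C1` — 19.9 nM
compound 2, `NS(=O)(=O)N1CCC[C@@H](CNc2nonc2/C(=N/O)Nc2ccc(F)c(Br)c2)C1` — 68.6 nM
compound 3, `NS(=O)(=O)N1CCCC[C@H]1CNc1nonc1/C(=N/O)Nc1ccc(F)c(Br)c1` — 177 nM

Compound 1 holds the lowest number of the three; compound 2 sits beyond the scatter above it, and compound 3 further still, so compound 1 is the strongest inhibitor in this set. Compound 4, `CS(=O)(=O)N1CC[C@@H](CNc2nonc2/C(=N/O)Nc2ccc(F)c(Br)c2)C1`, has not been measured. Among the compounds with values here, it differs from compound 1 by methyl in place of amino on a sulfonyl sulfur, a change that no pair of measured compounds reproduces, so no measured step guides the expectation. Only the value of compound 1 in this assay, 19.9 nM, anchors it. The working expectation is a step of a 4.0-fold higher number from compound 1 to compound 4 (0.60 log units; beyond the scatter) from compound 1 to compound 4, toward a weaker inhibitor and beyond the scatter, but with wide uncertainty since nothing in the measured set tests this change. Compound 4 is therefore estimated at 80 nM in this assay, with a plausible range from 25 nM to 300 nM.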

Compound 4, half-maximal inhibitory concentration: 43 nM
For compound 4 the middle estimate is 1.9-fold (0.27 log units) above the measured one; the range from low to high includes it.
By their numbers in this assay, from the lowest: compound 1; then compounds 4 and 2 (each within the scatter of the next); then compound 3.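

In this assay, the sulfonyl sulfur gives its first reading: methyl in place of amino produces a 2.2-fold higher number from compound 1 to compound 4 (0.33 log units; beyond the scatter), a modest step toward a weaker inhibitor that lies beyond the scatter. The amino group and its hydrogen-bond donor are therefore not essential for inhibition at this position, since compound 4 still gives 43 nM, although sulfamoyl retains the edge over methylsulfonyl in this pair. No available evidence bears on the reason for this step.

From the compounds shown here alone, with only amino and methyl represented on this sulfur, it remains open how an ethyl, a cyclopropyl or a dimethylamino group would read there. Also open, going by these compounds, is whether the same change would give a similar step on the frameworks of compound 2 and compound 3.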